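The source may hold more compounds than are shown below. What is called first, only, known or untested is meant among the compounds shown, and "the series" means these compounds.

Working notes on the series. Compound 1 `CCCCc1cnc(C(CCC)Cc2ccc(-c3ccccc3C(=O)O)cc2)[nH]1` gives 165 nM in an in vitro functional assay on cells for agonist activity at Bombesin receptor subtype-3 (Mus musculus), read by luminescence and calcium flux; on this read-out higher numbers stand for an effect only at larger amounts of compound and lower numbers for an effect already at smaller amounts. Compound 2 `CCCCc1cnc(CCCc2ccc(-c3ccccc3C(=O)O)cc2)[nH]1`, which carries a shorter chain on the same core, gives 382 nM in this assay. Going by the values given here, compound 3 `Cc1ccccc1Cc1cnc(CCc2ccc(-c3ccccc3C(=O)O)cc2)[nH]1` gives 9.3 nM in this assay, the lowest number of the three; its gaps to compound 1 and to compound 2 both lie beyond the scatter, so compound 3 is the most potent compound measured so far.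

Compound 4 `O=C(O)c1ccccc1-c1ccc(CCc2ncc(Cc3ccc(Cl)cc3)[nH]2)cc1` is not yet measured. It differs from compound 3 in one place: 4-chlorophenyl in place of 2-methylphenyl on a saturated chain carbon bound to an aromatic carbon. Among the compounds with values here, no pair of measured compounds shows this exchange, so no measured step can anchor it; the three measured compounds differ in the chain and in the group on the core rather than in the substituent on that ring. The change is expected to move the number of compound 4 only little, with a step from compound 3 of a 1.5-fold higher number from compound 3 to compound 4 (0.18 log units; within the scatter), within the scatter or slightly beyond it in either direction. In this assay compound 4 is expected to give about 14 nM, in a range from 4 nM to 50 nM.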

Compound 4, half-maximal effective concentration: 102 nM
The estimate for compound 4 lay 7.3-fold (0.86 log units) below the measured number; measured number outside the range, above it.
By their numbers in this assay, from the lowest: compound 3; then compounds 4 and 1 (each within the scatter of the next); then compound 2.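

In this assay, 4-chlorophenyl in place of 2-methylphenyl on a saturated chain carbon bound to an aromatic carbon comes with an 11-fold higher number from compound 3 to compound 4 (1.04 log units; beyond the scatter). Going by these compounds alone, this is the first measured step at this position, and it shows that the number responds strongly to this exchange, even though the two groups match in heavy atoms, carry no hydrogen-bond donors or acceptors and have no net charge. No measurement at hand bears on what lies behind the step.

The exchange alters both the ring substituent and its place on the ring, so the compounds shown do not separate the swap of methyl for chlorine from the change of place. From the compounds shown here alone, whether an unsubstituted phenyl or a methoxyphenyl at this position would give a number nearer to that of compound 3 or compound 4 also remains open.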